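Swapping the aryl group on the amine-bearing chain of compound 1

The compounds below may be only part of what the source reports. "The series", "measured", "known", "first", "only" and "open" are said of these compounds alone.

Compound 1 `O=S(=O)(NCCCNCc1ccccc1Cl)c1cc(C(F)(F)F)cc(C(F)(F)F)c1` is a sulfonamide whose chain ends in an amine carrying a 2-chlorophenyl-bearing carbon. Within the data shown here, in a functional assay on MIA PaCa-2 cells (Homo sapiens) for inhibition, read by MTT assay, with a stated time of 72 h (on this read-out lower numbers stand for stronger inhibition of growth and higher numbers for weaker inhibition of growth), compound 1 gives 11000 nM, the highest of the two numbers known here. Its nearest neighbour is compound 2 `O=S(=O)(NCCCCNCc1ccc(Br)cc1)c1cc(C(F)(F)F)cc(C(F)(F)F)c1`, which in this assay gives 2100 nM; the step of a 5.2-fold lower number from compound 1 to compound 2 (0.72 log units; beyond the scatter) shows that changing the chain end together with the aryl group lowers the number by a modest amount. Compound 3 `O=S(=O)(NCCCNCc1ccc(Cl)c(C(F)(F)F)c1)c1cc(C(F)(F)F)cc(C(F)(F)F)c1` keeps the chain of compound 1 and changes only the aromatic group: 4-chloro-3-(trifluoromethyl)phenyl in place of 2-chlorophenyl on a saturated chain carbon bound to an amine nitrogen. Among the measured compounds shown here, only the step from compound 1 to compound 2 bears on this, and it also altered the chain, so it is an imperfect guide; a modest lowering is nevertheless the most plausible expectation. For compound 3 the expected step is a 2.8-fold lower number from compound 1 to compound 3 (0.44 log units; beyond the scatter), giving an estimate of 4000 nM with a range from 1500 nM to 11000 nM.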

Compound 3, concentration for 50% growth inhibition: 7400 nM
Estimate against measurement, compound 3: 1.9-fold (0.27 log units) below, and the stated range covers the measured number.
By their numbers in this assay, from the lowest: compound 2; then compounds 3 and 1 (each within the scatter of the next).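

With the chain of compound 1 held fixed, putting 4-chloro-3-(trifluoromethyl)phenyl in place of 2-chlorophenyl on a saturated chain carbon bound to an amine nitrogen gives, in this assay, a 1.5-fold lower number from compound 1 to compound 3 (0.17 log units; within the scatter) and so no real difference in growth inhibition. This place on the chain therefore tolerates an aromatic group of 11 heavy atoms instead of 7, with an added trifluoromethyl, and the reading stays within the usual scatter. Nothing measured here explains why these two groups read alike.

Because compound 2 differs in both chain and aromatic group, it remains unclear which of those changes lies behind a 5.2-fold lower number from compound 1 to compound 2 (0.72 log units; beyond the scatter) in this assay. From the compounds shown here alone, how a pyridine ring or an unsubstituted phenyl would read at this place also remains open.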